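Series notes: chloro added on the benzylsulfanyl arm

The source may report more compounds than this note shows. Statements on the series, on what has been measured and on what is new or still open speak of the compounds shown alone.

Measured so far:
Compound 1 `COc1ccc(C2N=C(SCc3cccc(Cl)c3)NC(C)=C2C(=O)Nc2ccc(F)cc2)cc1OC`; in a functional assay on the whole organism (artery, strain albino) with Rattus norvegicus as the target, with a stated time of 360 min, at a dose of 10 mg/kg by the oral route (on this read-out higher numbers stand for more inhibition at the one dose given (going by the name of the read-out) and lower numbers for less inhibition), compound 1 gives 20.1%.
Compound 2 `CC1=C(C(=O)Nc2ccc(Br)cc2)C(c2ccc(Cl)cc2Cl)N=C(SCc2ccccc2)N1`; in this assay compound 2 gives 24.2%.

Of the compounds shown here, two have been measured, and they differ in more than one place, so no single step between measured compounds can be read off. Compound 2 and compound 1 lie within the scatter of each other on this assay; the numbers do not separate them, and neither can be said to show the higher or the lower inhibition in this assay.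

Compound 3 `CC1=C(C(=O)Nc2ccc(Br)cc2)C(c2ccc(Cl)cc2Cl)N=C(SCc2cccc(Cl)c2)N1` has not been measured. It arises from compound 2 by chloro in place of hydrogen on an aromatic carbon. Going by the values given here, compound 1 already carries a (3-chlorobenzyl)sulfanyl group on its own core, and its value sits within the scatter of compound 2, which is the only point of comparison available for this change.

On that basis the step in this assay from compound 2 to compound 3 is expected to be none beyond the scatter, an estimated a number 2.2 percentage points lower from compound 2 to compound 3 (within the scatter). Compound 3 is estimated at 22%, with a range from 10% to 35%.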

Compound 3, a percentage reported as inhibition, in the whole organism at one dose (the size of the read-out at that dose, not a potency): 20.6%
The estimate for compound 3 lay 1.4 percentage points above the measured number, within the range that was stated.
By their numbers in this assay, from the lowest: compounds 1, 3 and 2 (each within the scatter of the next).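

In this assay, chloro in place of hydrogen on an aromatic carbon of the benzylsulfanyl arm, meta to a large group, gives a number 3.6 percentage points lower from compound 2 to compound 3 (within the scatter), so at this position the change does not separate the two compounds at the one dose given. Going by these compounds alone, this is the first reading of the change with the rest of the structure held constant, as the earlier compounds differed in more than one place. No measurement at hand bears on the reason for this result.

An amine or a carboxylic acid on the same aromatic ring, or a longer chain in place of the benzyl group, remains to be read against compound 2, to show whether this arm responds to groups of another kind than chloro. Going by these compounds, one chloro at one place leaves the other ring positions open, and a single-dose percentage speaks only to the size of the read-out at that dose, so potency across the series also stays open.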